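The source may report more compounds than this note shows. Statements on the series, on what has been measured and on what is new or still open speak of the compounds shown alone.

Measured so far:
compound 1 `CC(C(=O)N1CCN(c2ccc(F)cc2)CC1)N1C(=O)CCC1=O` — 75%
compound 2 `CCC(C(=O)N1CCN(c2cccc(C)c2)CC1)N1C(=O)CCC1=O` — 50%

In a functional assay on the whole organism (strain Swiss) with Mus musculus as the target, in the maximal electroshock model, with a stated time of 0.25 h, at a dose of 100 mg/kg by the intraperitoneal route (a lower number here means a weaker effect, a higher number a stronger effect of the compound at the dose given), compound 1 gives 75%, the highest of the two numbers. Compound 2 gives 50%, a gap beyond the scatter. Within the data shown here, no pair of measured compounds differs in a single place, so no measured step is available to read the change against. Compound 3 `CC(C(=O)N1CCN(c2cccc(Cl)c2)CC1)N1C(=O)CCC1=O` differs from compound 1 by 3-chlorophenyl in place of 4-fluorophenyl on an amine nitrogen in a ring. With nothing measured for this kind of exchange, the expected step of a number 10 percentage points lower from compound 1 to compound 3 (within the scatter) is small, within the scatter, leaning slightly downward. Compound 3 is expected to give about 65%, with a range from 35% to 90%.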

Compound 3, a percentage reported as activity, at one dose (the size of the read-out at that dose, not a potency): 50%
Estimate against measurement, compound 3: 15 percentage points above, and the stated range covers the measured number.
By their numbers in this assay, from the lowest: compounds 2 and 3 (each within the scatter of the next); then compound 1.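

In this assay, among these compounds, the exchange of 4-fluorophenyl for 3-chlorophenyl on the amine nitrogen in the ring gives the first single-place reading: a number 25 percentage points lower from compound 1 to compound 3 (beyond the scatter). The group on this nitrogen thus affects the read-out at the dose given. The exchange changes both the halogen and its place on the phenyl ring, so the step cannot be assigned to either change alone, and nothing on hand gives a cause for it.

Open, going by these compounds, is how 3-fluorophenyl or 4-chlorophenyl would read, since either would separate the halogen from its place. Also open, on these data alone, is how unsubstituted phenyl or a methoxy-bearing phenyl would read on this nitrogen.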